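Swapping a chlorobenzyl for a dimethoxybenzyl group

The source may hold more compounds than are shown below. What is called first, only, known or untested is meant among the compounds shown, and "the series" means these compounds.

Compound 3 `COc1ccc(-c2nn(-c3ccccc3)cc2C(=O)NCc2cn(Cc3ccc(Cl)cc3)nn2)cc1` gives the highest number of the three measured compounds in a functional assay on HeLa cells (Homo sapiens) for antiproliferative activity, read by sulforhodamine B assay, with a stated time of 48 h (on this read-out lower numbers stand for stronger inhibition of growth and higher numbers for weaker inhibition of growth), with 6400 nM. Within the data shown here, compound 2 `COc1ccc(-c2nn(-c3ccccc3)cc2C(=O)NCc2cn(Cc3ccc(F)cc3)nn2)cc1` gives 500 nM, and the single change a 13-fold higher number from compound 2 to compound 3 (1.11 log units; beyond the scatter) shows how far one small swap on the benzyl group can move this assay. Compound 1 `COc1cc(Cn2cc(CNC(=O)c3cn(-c4ccccc4)nc3-c3ccc(Cl)cc3)nn2)cc(OC)c1` gives 730 nM; it already carries the 3,5-dimethoxybenzyl group, though on a different core. Compound 4 `COc1ccc(-c2nn(-c3ccccc3)cc2C(=O)NCc2cn(Cc3cc(OC)cc(OC)c3)nn2)cc1` arises from compound 3 by 3,5-dimethoxyphenyl in place of 4-chlorophenyl on a saturated chain carbon bound to an aromatic nitrogen. Among the measured compounds shown here, no measured step covers this exact change, but compound 1 and compound 2 both sit well under compound 3 in this assay. Compound 4 is therefore expected to show an 8.0-fold lower number from compound 3 to compound 4 (0.90 log units; beyond the scatter). Compound 4 is estimated at 800 nM, within 250 nM to 3000 nM.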

Compound 4, concentration for 50% growth inhibition: 12400 nM
Compound 4: middle estimate off by 16-fold (1.19 log units), on the low side; measured number outside the range, above it.
By their numbers in this assay, from the lowest: compounds 2 and 1 (each within the scatter of the next); then compounds 3 and 4 (each within the scatter of the next).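

In this assay, the 3,5-dimethoxybenzyl group behaves no differently from the 4-chlorobenzyl group on this core, with a 1.9-fold higher number from compound 3 to compound 4 (0.29 log units; within the scatter), while the 4-fluorobenzyl group stays clearly apart, with a 25-fold higher number from compound 2 to compound 4 (1.39 log units; beyond the scatter). With the 3,5-dimethoxybenzyl group held fixed, methoxy in place of chloro on an aromatic carbon gives a 17-fold higher number from compound 1 to compound 4 (1.23 log units; beyond the scatter), so the low number of compound 1 does not carry over to this core. No measurement here offers a reason for these gaps.

From the compounds shown here alone, whether a plain benzyl or a 4-bromobenzyl group would sit with compound 2 or with compound 3 stays open. So does the effect of the 4-fluorobenzyl group on the core of compound 1.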